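Aryl ketone exchanges on the shared core: compound 4

The source may report more compounds than this note shows. Statements on the series, on what has been measured and on what is new or still open speak of the compounds shown alone.

The series keeps the core of compound 1 `COc1cc(-c2nnc3n2NC(c2ccco2)C(C(=O)c2ccc(F)c(F)c2)S3)cc(OC)c1OC` and varies only the aryl group on the carbonyl carbon. In a functional assay on A549 cells (Homo sapiens) for cytotoxicity, read by MTT assay, with a stated time of 48 h (on this read-out higher numbers stand for weaker inhibition and lower numbers for stronger inhibition), compound 1 gives 93700 nM. Compound 2 `COc1cc(-c2nnc3n2NC(c2ccco2)C(C(=O)c2ccccc2C)S3)cc(OC)c1OC` carries 2-methylphenyl there, and in this assay compound 2 gives 80000 nM. Compound 3 `COc1cccc(C(=O)C2Sc3nnc(-c4cc(OC)c(OC)c(OC)c4)n3NC2c2ccco2)c1` carries 3-methoxyphenyl. Among the compounds with values here, for compound 3 this assay returns only a limit of the assay, > 100000 nM; it is the one value among the three that sits at the limit of > 100000 nM in this assay, at which 1 of the 3 values shown sits. Compound 3 therefore stands with compounds 1 and 2 at the weak end of this read-out, but without a number of its own.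

Compound 4 `COc1cc(-c2nnc3n2NC(c2ccco2)C(C(=O)c2ccc([N+](=O)[O-])cc2)S3)cc(OC)c1OC` differs from compound 3 in one place: 4-nitrophenyl in place of 3-methoxyphenyl on a carbonyl carbon. The measured steps that bear on this are all aryl exchanges on the same carbonyl carbon: a 1.2-fold lower number from compound 1 to compound 2 (0.07 log units; within the scatter), an at least 1.0-fold higher number from compound 1 to compound 3 (0.02 log units; that floor lies within the scatter) and an at least 1.2-fold higher number from compound 2 to compound 3 (0.09 log units; that floor lies within the scatter). None of them moves beyond the scatter, and the whole series sits at weak inhibition. Within the data shown here, no measured step concerns a nitro group. The expected step from compound 3 to compound 4 in this assay is therefore none beyond the scatter, an at least 1.0-fold lower number from compound 3 to compound 4 (0.02 log units; that floor lies within the scatter). Compound 4 is expected to give about 95000 nM in this assay, between 50000 nM and 200000 nM, with a fair chance that only a limit is again reported.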

Compound 4, half-maximal inhibitory concentration: > 100000 nM
Compound 4 ended at the assay's limit; the forecaster's own chance of this, stated with the estimate: 50%; middle value at least 1.0-fold (0.02 log units) away from the limit.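

Compound 4 adds a second aryl exchange that ends in a limit of the assay rather than a number, and here the incoming 4-nitrophenyl ring differs from the earlier aryl groups in bringing a nitrogen and a double bond outside aromatic rings. In this assay, the readable comparisons are an at least 1.2-fold higher number from compound 2 to compound 4 (0.09 log units; that floor lies within the scatter) and an at least 1.0-fold higher number from compound 1 to compound 4 (0.02 log units; that floor lies within the scatter); the step between the two limit compounds cannot be read, so no order between the 3-methoxyphenyl and 4-nitrophenyl groups can be stated. Among the aryl exchanges on this carbonyl carbon, a nitro-bearing ring therefore gives no sign of separating from the weak end of the series, and the share of values at the limit has grown: the limit of > 100000 nM in this assay, at which 2 of the 4 values shown sit.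

Going by these compounds, whether a 4-aminophenyl group, a carboxylic acid on the ring or a longer alkyl chain in place of the aryl group on the carbonyl carbon would bring a number clearly beyond the scatter remains open. Also open is whether any change elsewhere on the shared core would give stronger inhibition, since all the compounds shown vary at this one place.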